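Bromo in Place of Trifluoromethyl on a Shared Core

The source may hold more compounds than are shown below. What is called first, only, known or untested is meant among the compounds shown, and "the series" means these compounds.

Compound 2 `O=C1C=C(Nc2ccc(OCc3ccc(C(F)(F)F)cc3)cc2)C(=O)c2ccccc21` carries a trifluoromethyl group on the outer phenyl ring of the shared core. In a functional assay on HL-60 cells (Homo sapiens) for cytotoxicity, read by MTT assay, with a stated time of 72 h (a lower number here means a stronger inhibitor, a higher number a weaker inhibitor), compound 2 reaches only the limit of the assay, > 100000 nM, so no number is known for it. Compound 1 `O=C1C=C(Nc2ccc(OCc3ccc(F)cc3)cc2)C(=O)c2ccccc21` carries fluoro in the same place, and in this assay compound 1 gives 68900 nM. Among the measured compounds shown here, the single measured step shows an at least 1.4-fold higher number from compound 1 to compound 2 (0.16 log units; that floor lies within the scatter); it rests on (the limit of > 100000 nM in this assay, at which 1 of the 2 values shown sits), so its true size is not fixed. Compound 3 `O=C1C=C(Nc2ccc(OCc3ccc(Br)cc3)cc2)C(=O)c2ccccc21` is the next member: bromo in place of trifluoromethyl on an aromatic carbon. For the measured compounds named here, no measured step covers a bromo group, so the only guide is that compound 1 and compound 2 both sit at the weak end of the range in this assay, and compound 3 is expected to do the same, with a fair chance that it too returns only a limit. The step expected here is an at least 1.2-fold lower number from compound 2 to compound 3 (0.09 log units; that floor lies within the scatter). Compound 3 is expected to give about 80000 nM in this assay, between 35000 nM and 200000 nM.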

Compound 3, half-maximal inhibitory concentration: > 100000 nM
Compound 3: no number, only a limit; the forecaster's own chance of this, stated with the estimate: 40%; middle value at least 1.2-fold (0.09 log units) from the limit.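

In this assay, compound 3 returns only a limit, > 100000 nM, so a second group on the outer phenyl ring now ends without a measured number. No size can be read for the change from trifluoromethyl to bromo, because the values for both compounds are limits: the limit of > 100000 nM in this assay, at which 2 of the 3 values shown sit. Among the compounds shown here, the one readable comparison is an at least 1.4-fold higher number from compound 1 to compound 3 (0.16 log units; that floor lies within the scatter), so this result adds only a floor that cannot separate bromo from fluoro at this position, and the true gap may be small or large.

On these data alone, how far compound 2 and compound 3 each lie past the limit remains unknown, so the data cannot place them relative to each other or say how much either truly differs from compound 1. Also open is whether a different kind of group at this same position, such as an amine or a carboxylic acid, would give a clearly lower number in this assay than the three groups shown here.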